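Swapping Fluoro for Trifluoromethyl on Compound 1

A few compounds are considered here, and "the series" means these few. Any claim that something is new, unique, unknown or untested is made for them only; others in the source may bear on it.

Compounds measured in a functional assay on HCT-116 cells (Homo sapiens) for antiproliferative activity, read by MTT assay, with a stated time of 24 h; a lower number here means a stronger inhibitor, a higher number a weaker inhibitor:
Compound 1, `COc1ccc(C(=O)/C=C/c2ccc(F)cc2)c2c1C=CC(C)(C)O2`: compound 1 gives > 10000 nM, which is a limit of the assay and not a number.
Compound 2, `COc1ccc(C(=O)/C=C/c2ccc3ccccc3n2)c2c1C=CC(C)(C)O2`: compound 2 gives 4530 nM.
Compound 3, `COc1ccc(C(=O)/C=C/c2cccc([N+](=O)[O-])c2)c2c1C=CC(C)(C)O2`: compound 3 gives 8050 nM.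

Of the three, compound 1 is the one that sits at the limit of > 10000 nM in this assay, at which 1 of the 3 values shown sits, so its standing is known only as a bound, while compound 2 and compound 3 give numbers. For the measured compounds named here, the single measured step that starts from compound 1 is an at least 1.2-fold lower number from compound 1 to compound 3 (0.09 log units; that floor lies within the scatter), whose floor lies within the scatter and therefore shows no change that can be trusted. Compound 4, `COc1ccc(C(=O)/C=C/c2ccc(C(F)(F)F)cc2)c2c1C=CC(C)(C)O2`, differs from compound 1 by trifluoromethyl in place of fluoro on an aromatic carbon. Going by the values given here, no measured step exchanges fluoro for trifluoromethyl; the step from compound 1 to compound 3 swaps the whole aryl group and is the only guide, and it is silent. In this assay one therefore expects an at least 1.1-fold lower number from compound 1 to compound 4 (0.04 log units; that floor lies within the scatter), a change no larger than the usual scatter. Compound 4 is estimated at 9000 nM in this assay, with a range from 3500 nM to 25000 nM, and a real chance that only a limit is reported.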

Compound 4, half-maximal inhibitory concentration: > 10000 nM
Compound 4: only a limit was reported; the forecaster's own chance of this, stated with the estimate: 50%; middle value at least 1.1-fold (0.04 log units) away from the limit.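

In this assay compound 4 gives > 10000 nM, a limit of the assay and not a number. Compound 1 also stands at a limit, and the step between compound 1 and compound 4 cannot be read. The compounds shown leave open how far, if at all, trifluoromethyl in place of fluoro moves the number.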